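The source may report more compounds than this note shows. Statements on the series, on what has been measured and on what is new or still open speak of the compounds shown alone.

Working notes on the series around the shared core of compound 1 `COc1ccc(/C=C/C(=O)c2ccc(OC)c3c2OC(C)(C)C=C3)cc1O`, read in an ADME assay on L02 cells (Homo sapiens) for cytotoxicity, read by MTT assay; a higher number here means a weaker inhibitor, a lower number a stronger inhibitor. Compound 1 gives > 10000 nM, which is a limit and not a number. Compound 2 `COc1ccc(/C=C/C(=O)c2ccc(OC)c3c2OC(C)(C)C=C3)cc1OC(=O)C(C)C` gives > 10000 nM, again a limit. Compound 3 `C=CC(=O)Oc1cc(/C=C/C(=O)c2ccc(OC)c3c2OC(C)(C)C=C3)ccc1OC` gives > 10000 nM, also a limit. Compound 3 therefore has no number of its own, and its place in the series is the limit of > 10000 nM in this assay, at which 3 of the 3 values shown sit.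

Compound 4 `COc1ccc(/C=C/C(=O)c2ccc(OC)c3c2OC(C)(C)C=C3)cc1OC(=O)CCl` carries chloromethyl in place of vinyl on a carbonyl carbon.

Within the data shown here, three measured steps bear on this change. The closest is a step that the two limits leave unreadable from compound 2 to compound 3, at the same carbonyl carbon. The other two, a step that the two limits leave unreadable from compound 1 to compound 2 and a step that the two limits leave unreadable from compound 1 to compound 3, sit on an oxygen on an aromatic ring. None of them gives a size, so none can be carried over as a number. No step beyond the scatter is expected in this assay, and a further limit is the most likely reading. This expectation rests on compound 3, whose limit is > 10000 nM. The estimated step is a step that the limit leaves unreadable from compound 3 to compound 4. For compound 4 the estimated value is 15000 nM, with an expected range of 6000 nM to 40000 nM.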

Compound 4, half-maximal inhibitory concentration: > 10000 nM
Compound 4 ended at the assay's limit; the forecaster's own chance of this, stated with the estimate: 80%; the middle value lies beyond the limit too.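

In this assay compound 4 gives > 10000 nM, which is a limit. Among these compounds, no step from compound 1, compound 2 or compound 3 to compound 4 can be read, as all four compounds share one limit: the limit of > 10000 nM in this assay, at which 4 of the 4 values shown sit.

The compounds shown leave open whether any change on the carbonyl carbon or the aromatic oxygen alters the read-out.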